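A few compounds are considered here, and "the series" means these few. Any claim that something is new, unique, unknown or untested is made for them only; others in the source may bear on it.

Of the compounds shown here, three built on one shared core have so far been tested in an assay on CHO-K1 cells for displacement of a labelled ligand from adenosine receptor A1 (Homo sapiens), tested at 10 uM; a higher number here means more inhibition at the concentration tested (going by the name of the read-out), a lower number less inhibition. Compound 1 `CC(=O)c1cccc(-c2sc(N)c(C(=O)c3ccccc3)c2-c2cccc(C(F)(F)F)c2)c1` gives 33.1%. Compound 2 `CC(=O)c1ccc(-c2sc(N)c(C(=O)c3ccccc3)c2-c2cccc(C(F)(F)F)c2)cc1` gives 25.6%, and the step of a number 7.5 percentage points lower from compound 1 to compound 2 (within the scatter) is within the scatter. Compound 3 `CCOC(=O)c1c(N)sc(-c2cccc(C(C)=O)c2)c1-c1cccc(C(F)(F)F)c1` gives 68.9%, the highest of the three numbers; the step of a number 35.8 percentage points higher from compound 1 to compound 3 (beyond the scatter) is large and lies beyond the scatter, and compound 2 stands further from compound 3 still.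

Compound 4 `CCOC(=O)c1c(N)sc(-c2ccc(Cl)cc2)c1-c1cccc(C(F)(F)F)c1` has not yet been measured in this assay . It differs from compound 3 by 4-chlorophenyl in place of 3-acetylphenyl on an aromatic carbon. Among the compounds with values here, of the measured steps, only the one from compound 1 to compound 2 touches the same aromatic group, and there the change a number 7.5 percentage points lower from compound 1 to compound 2 (within the scatter) stayed within the scatter. The step from compound 1 to compound 3 concerns a different part of the molecule and does not bear on this exchange. Within the data shown here, no measured pair swaps an acetylphenyl for a chlorophenyl, so the size and direction of the step are uncertain.

The step of a number 8.9 percentage points lower from compound 3 to compound 4 (within the scatter) is therefore expected to be modest, with a wide range in either direction. For compound 4 the estimated value in this assay is 60%, expected to fall between 35% and 85%.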

Compound 4, a percentage reported as inhibition, at one concentration (the size of the read-out at that concentration, not a potency): 58.4%
Compound 4: the middle estimate sits 1.6 percentage points above what was measured, and the stated range covers the measured number.
By their numbers in this assay, from the lowest: compounds 2 and 1 (each within the scatter of the next); then compound 4; then compound 3.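

At this aromatic carbon next to the ring sulfur, with the ethoxycarbonyl group in place, the exchange of 3-acetylphenyl for 4-chlorophenyl gives a number 10.5 percentage points lower from compound 3 to compound 4 (beyond the scatter) in this assay, a modest step, but unlike the acetyl shift between compound 1 and compound 2, it lies beyond the scatter, so this position does register a change of its aryl group. The acetyl carbonyl is also not required for a sizeable reading at the tested concentration, as compound 4, which carries chlorine and has no hydrogen-bond acceptor in this group, still gives 58.4%. Nothing measured here explains why the number falls.

This exchange alters both the group on the phenyl ring and where it sits, so the compounds shown cannot say which of the two matters, and a 3-chlorophenyl or 4-acetylphenyl group alongside the ethoxycarbonyl would pull them apart. Also open, going by these compounds, is how this position responds to groups of a different kind, such as a carboxylic acid or an aminomethyl group on the phenyl ring, or a plain unsubstituted phenyl.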